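Iodo to Phenyl on Two Related Cores

This account rests on a few compounds, and the source may have more. Where it says the series, first, only, none or still open, it means among the compounds named here.

Compound 2 `Cc1nc(N)c2c(I)cn([C@@H]3O[C@H](CO)[C@@H](O)[C@H]3O)c2n1` is the reference point of this small series. In a functional assay on HL-60 cells (Homo sapiens) for antiproliferative activity, read by XTT assay, with a stated time of 72 h (on this read-out lower numbers stand for stronger inhibition and higher numbers for weaker inhibition), compound 2 gives 2050 nM. Compound 1 `Cc1nc(N)c2c(-c3ccccc3)cn([C@@H]3O[C@H](CO)[C@@H](O)[C@H]3O)c2n1` differs from it by phenyl in place of iodo on an aromatic carbon. In this assay compound 1 reaches only a limit, > 20000 nM. That single change thus produced an at least 9.7-fold higher number from compound 2 to compound 1 (0.98 log units; beyond the scatter), a loss of activity rather than a gain.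

Compound 3 `CNc1ncnc2c1c(I)cn2[C@@H]1O[C@H](CO)[C@@H](O)[C@H]1O` is built from the same atoms as compound 2, joined differently; the difference between the two cores is not broken down here. In this assay compound 3 also gives only a limit, > 20000 nM.

Compound 4 `CNc1ncnc2c1c(-c1ccccc1)cn2[C@@H]1O[C@H](CO)[C@@H](O)[C@H]1O` has not yet been measured. Within the data shown here, it differs from compound 3 by phenyl in place of iodo on an aromatic carbon, which is the same change as the one made from compound 2 to compound 1, at the same place on the five-membered ring. Since compound 3 already sits at the limit of > 20000 nM in this assay, at which 2 of the 3 values shown sit, and the earlier step moved the number upward beyond the scatter, the expected step is a step that the limit leaves unreadable from compound 3 to compound 4, meaning no return to measurable activity. Compound 4 is therefore estimated at roughly 60000 nM, most probably reported again only as a limit, within an expected range from 20000 nM to 300000 nM.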

Compound 4, half-maximal inhibitory concentration: > 20000 nM
Compound 4 gave a limit, no number (the forecaster's own chance of this, stated with the estimate: 90%); the middle value is on the limit's open side.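

Compound 4 gives only a limit in this assay, as compound 3 does, so no step from compound 3 to compound 4 can be read: the limit of > 20000 nM in this assay, at which 3 of the 4 values shown sit.

The compounds shown leave open whether phenyl in place of iodo changes the activity at all on the core of compound 3, and so whether it acts there as it does on the core of compound 2.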